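Formyl in Place of Ethyl on the Pendant Phenyl

The source may hold more compounds than are shown below. What is called first, only, known or untested is meant among the compounds shown, and "the series" means these compounds.

Of the compounds shown here, three on a shared core have been measured: compound 1 `c1ccc(-c2cn3ccnc3c(-c3ccc4ncn(C5CCCCC5)c4c3)n2)cc1`, compound 2 `Clc1ccc(-c2cn3ccnc3c(-c3ccc4ncn(C5CCCCC5)c4c3)n2)cc1` and compound 3 `CCc1ccc(-c2cn3ccnc3c(-c3ccc4ncn(Cc5ccccc5)c4c3)n2)cc1`. In a functional assay on HCT-116 cells (Homo sapiens) for inhibition, read by sulforhodamine B assay, with a stated time of 48 h, tested at 10 uM (on this read-out lower numbers stand for less inhibition and higher numbers for more inhibition at the one concentration tested (going by the name of the read-out)), compound 1 gives 59.5%, compound 2 gives 7.34%, and compound 3 gives 61.2%. Compound 3 stands highest of the three, but its gap to compound 1 lies within the scatter, while its gap to compound 2 lies well beyond it. Within the data shown here, the single step between neighbours reads a number 52.2 percentage points lower from compound 1 to compound 2 (beyond the scatter), a large drop for a small change on the pendant phenyl ring.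

Compound 4 `O=Cc1ccc(-c2cn3ccnc3c(-c3ccc4ncn(Cc5ccccc5)c4c3)n2)cc1` differs from compound 3 by formyl in place of ethyl on an aromatic carbon. Among the measured compounds shown here, no measured step covers this exchange; the chloro step is the only one on that ring, and it shows that one substituent there can shift the read-out by half its range. He therefore expects a downward step of uncertain size, a number 21.2 percentage points lower from compound 3 to compound 4 (beyond the scatter), with a wide band. For compound 4 he estimates 40%, between 10% and 70%.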

Compound 4, a percentage reported as inhibition, at one concentration (the size of the read-out at that concentration, not a potency): 92.6%
For compound 4 the middle estimate is 52.6 percentage points below the measured one; measured number outside the range, above it.
By their numbers in this assay, from the lowest: compound 2; then compounds 1 and 3 (each within the scatter of the next); then compound 4.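

Among these compounds, a step of a number 31.4 percentage points higher from compound 3 to compound 4 (beyond the scatter) in this assay shows that the place para to a large group on the pendant phenyl can carry the read-out upward as well as downward, whereas the only earlier step on this ring (a number 52.2 percentage points lower from compound 1 to compound 2 (beyond the scatter)) went down. The change from 4-ethylphenyl to 4-formylphenyl swaps only two heavy atoms for two and brings in one hydrogen-bond acceptor, yet the step is large, though the two steps stand on compounds that also differ elsewhere on the shared core. No measurement at hand explains the rise.

The compounds shown do not tell whether the rise belongs to formyl itself, since a nitrile, a carboxylic acid or a hydroxymethyl group at this place is not among them. They also leave open whether formyl would give a similar step on the cyclohexyl compounds.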